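The compounds below may be only part of what the source reports. "The series", "measured", "known", "first", "only" and "open" are said of these compounds alone.

Compound 1 `O=C(Nc1cccnc1)c1ccccc1OCc1ccccc1F` gives 3500 nM in an assay on lysate for inhibition of phosphatidylcholine:ceramide cholinephosphotransferase 2 (Homo sapiens), read by HPLC, with stated times of 30 min and 2 h; on this read-out higher numbers stand for weaker inhibition and lower numbers for stronger inhibition. Compound 2 `N#Cc1ccccc1COc1ccccc1C(=O)Nc1cccnc1` gives 31800 nM in this assay.

Among the compounds with values here, of these two numbers compound 2 stands highest, and the only measured step, a 9.1-fold higher number from compound 1 to compound 2 (0.96 log units; beyond the scatter), came from putting a cyano in place of fluoro on an aromatic carbon. Compound 3 `O=C(Nc1cccnc1)c1ccccc1OCc1ccccc1OCCCCCCl` differs from compound 2 by (5-chloropentyl)oxy in place of cyano on an aromatic carbon. Within the data shown here, no measured step exchanges a cyano for such a chain, so the size of that one step is the only guide, and the direction stays uncertain. Compound 3 is expected to give 8000 nM, within 1500 nM to 40000 nM. The expected step is a 4.0-fold lower number from compound 2 to compound 3 (0.60 log units; beyond the scatter), a somewhat lower number.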

Compound 3, half-maximal inhibitory concentration: 670 nM
Compound 3: middle estimate off by 12-fold (1.08 log units), on the high side; measured number outside the range, below it.
By their numbers in this assay, from the lowest: compound 3; then compound 1; then compound 2.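

Until now, this position had held only the small fluoro and cyano groups, and the swap between them weakened inhibition. The much larger (5-chloropentyl)oxy chain on this aromatic carbon brings a 47-fold lower number from compound 2 to compound 3 (1.68 log units; beyond the scatter) and a 5.2-fold lower number from compound 1 to compound 3 (0.72 log units; beyond the scatter) and gives the strongest inhibition of the three, so a long chain here is not merely accepted but goes with a lower number. Nothing measured here bears on the reason for this gain.

The compounds shown cannot separate the roles of the oxygen, the chain length and the end chlorine. Methoxy, unchlorinated pentyloxy or a longer chain ending in an amine would each test a different part.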